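A few compounds are considered here, and "the series" means these few. Any claim that something is new, unique, unknown or untested is made for them only; others in the source may bear on it.

In a functional assay on HL-60 cells (Homo sapiens) for antiproliferative activity, read by XTT assay, with a stated time of 72 h (on this read-out lower numbers stand for stronger inhibition and higher numbers for weaker inhibition), compound 1 `Cc1ncnc2c1c(-c1ccsc1)cn2[C@@H]1O[C@H](CO)[C@@H](O)[C@H]1O` gives 350 nM, a measured number. Compound 2 `CNc1ncnc2c1c(I)cn2[C@@H]1O[C@H](CO)[C@@H](O)[C@H]1O` stands apart from it, reaching only a limit of the assay, > 20000 nM. The next compound to be tested, compound 3 `Cc1ncnc2c1c(I)cn2[C@@H]1O[C@H](CO)[C@@H](O)[C@H]1O`, keeps the iodine of compound 2 and alters a single group. The change is methyl in place of methylamino on an aromatic carbon, next to the ring nitrogen.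

Going by the values given here, no step between measured compounds shows what this exchange is worth, and the starting point is a limit rather than a number, so any forecast is loose. Among the compounds with values here, the one pointer is a compound that also has a methyl on that carbon but lacks the iodine: compound 1, with its 350 nM. On that basis, a shift towards stronger inhibition in this assay, well beyond the usual scatter, is expected rather than no change. The expected size is an at least 13-fold lower number from compound 2 to compound 3 (1.12 log units; beyond the scatter). Compound 3 is estimated at 1500 nM, with an expected range from 200 nM to 15000 nM.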

Compound 3, half-maximal inhibitory concentration: 2650 nM
Compound 3: the middle estimate sits 1.8-fold (0.25 log units) below what was measured; measured number inside the range.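

In this assay, methyl in place of methylamino on the aromatic carbon next to the ring nitrogen gives an at least 7.5-fold lower number from compound 2 to compound 3 (0.87 log units; beyond the scatter); with the iodo group held in common, this single exchange moves the series from a limit of the assay to a measured number. That step gives only a minimum for the size of the exchange, not its full size, since one end of it is a limit: the limit of > 20000 nM in this assay, at which 1 of the 3 values shown sits. With the methyl group held in common, iodo in place of thiophen-3-yl gives a 7.6-fold higher number from compound 1 to compound 3 (0.88 log units; beyond the scatter), which shows that the activity also depends on the second place of change and that the methyl group alone does not set the value.

From the compounds shown here alone, the true size of the step from methylamino remains open, as does whether an unsubstituted amine, an ethyl group or a longer chain on that carbon would read closer to methyl or to methylamino. Also open, going by these compounds, is whether thiophen-3-yl would give a measured number with methylamino on that carbon, or whether its effect holds only alongside the methyl group.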